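Swapping an Ether Tail for a Cyclopentylamine

The source may report more compounds than this note shows. Statements on the series, on what has been measured and on what is new or still open speak of the compounds shown alone.

Among the compounds with values here, compound 2 `C=C[C@]1(C)CC[C@@H](C(=C)COCCOC)C[C@H]1C(=C)C` gives 238000 nM in a functional assay on HeLa cells (Homo sapiens) for antiproliferative activity, read by WST assay, with a stated time of 24 h (on this read-out lower numbers stand for stronger inhibition and higher numbers for weaker inhibition), the highest of the two numbers measured so far; compound 1 `C=C[C@]1(C)CC[C@@H](C(=C)COCC)C[C@H]1C(=C)C` gives 106000 nM in this assay. Within the data shown here, the one measured step, a 2.2-fold higher number from compound 1 to compound 2 (0.35 log units; beyond the scatter), concerns a different change, so no measured step speaks directly to the change studied here. Among the measured compounds shown here, compound 3 `C=C[C@]1(C)CC[C@@H](C(=C)CNC2CCCC2)C[C@H]1C(=C)C` differs from compound 2 as follows: cyclopentylamino in place of 2-methoxyethoxy on a saturated chain carbon bound to a double-bonded chain carbon With no direct precedent, the expectation rests on the modest spread between compound 1 and compound 2 and on the large starting number of compound 2 at 238000 nM, which leaves room for a lower value. A step toward a lower number is therefore expected, a 4.0-fold lower number from compound 2 to compound 3 (0.60 log units; beyond the scatter), though with wide uncertainty. Compound 3 is estimated at 60000 nM, in a range from 15000 nM to 240000 nM.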

Compound 3, half-maximal inhibitory concentration: 520 nM
Beside the measured number, compound 3's estimate is 120-fold (2.06 log units) above it; the whole stated range lies above it.
By their numbers in this assay, from the lowest: compound 3; then compound 1; then compound 2.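

In this assay, the saturated chain carbon bound to a double-bonded chain carbon proves far more sensitive than the change between two ether tails suggested, which gave only a 2.2-fold higher number from compound 1 to compound 2 (0.35 log units; beyond the scatter): cyclopentylamino in place of 2-methoxyethoxy gives a 460-fold lower number from compound 2 to compound 3 (2.66 log units; beyond the scatter), and cyclopentylamino in place of ethoxy gives a 200-fold lower number from compound 1 to compound 3 (2.31 log units; beyond the scatter). The swap alters several things at once, since nitrogen replaces the ether oxygen, a five-membered ring enters and a hydrogen-bond donor appears, so these steps cannot assign the change to any one of them. No measured evidence here accounts for the size of the step.

The compounds shown leave open whether the nitrogen or the ring matters more, a question that diethylamino or cyclopentyloxy at this position would address. They also leave open how ring size counts, as with cyclohexylamino.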